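Changing the side chain from sec-butyl to carbamoylmethyl

A few compounds are considered here, and "the series" means these few. Any claim that something is new, unique, unknown or untested is made for them only; others in the source may bear on it.

Three compounds built on one shared core were tested in a functional assay on the whole organism (Tail, strain ICR) with Mus musculus as the target, in the tail flick test, with a stated time of 120 min, at a dose of 25 umol/kg by the oral route; a higher number here means a stronger effect of the compound at the dose given, a lower number a weaker effect. Compound 1 `O=C(O)[C@@H]1CCCN1C(=O)CN(c1nc(Cl)nc2[nH]cnc12)C1CC1` gives 23.6%, compound 2 `O=C(CN(c1ncnc2c1ncn2C1CCCCO1)C1CC1)NCC(=O)OCc1ccccc1` gives 17.2%, and compound 3 `CC[C@H](C)[C@H](NC(=O)CN(c1ncnc2c1ncn2C1CCCCO1)C1CC1)C(=O)OCc1ccccc1` gives 20.4%, a number that lies between those of compound 2 and compound 1 and within the scatter of each. For the measured compounds named here, the one measured step, a number 3.2 percentage points higher from compound 2 to compound 3 (within the scatter), touched the same saturated chain carbon that changes again here. Compound 4 `NC(=O)C[C@H](NC(=O)CN(c1ncnc2c1ncn2C1CCCCO1)C1CC1)C(=O)OCc1ccccc1` differs from compound 3 as follows: carbamoylmethyl in place of sec-butyl on a saturated chain carbon bound to an amide-type nitrogen and a carbonyl carbon. Going by the values given here, no measured step swaps sec-butyl for carbamoylmethyl, so that earlier step, itself within the scatter, is the only guide. Compound 4 is therefore expected to give 19%, between 8% and 30%. The expected step of a number 1.4 percentage points lower from compound 3 to compound 4 (within the scatter) stays within the scatter.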

Compound 4, a percentage reported as activity, at one dose (the size of the read-out at that dose, not a potency): 29.2%
Estimate against measurement, compound 4: 10.2 percentage points below; the range from low to high includes it.
By their numbers in this assay, from the lowest: compounds 2, 3, 1 and 4 (each within the scatter of the next, the first and the last beyond it).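

In this assay, for the compounds shown here, putting carbamoylmethyl on this saturated chain carbon bound to an amide-type nitrogen and a carbonyl carbon gives a number 12 percentage points higher from compound 2 to compound 4 (beyond the scatter), the first step at this position to pass the usual scatter, though only modestly. Exchanging sec-butyl for carbamoylmethyl gives a number 8.8 percentage points higher from compound 3 to compound 4 (within the scatter), so these two side chains cannot be told apart in this test. No measurement available here explains the step. As far as these compounds go, whether hydroxymethyl or a longer chain ending in an amine at this carbon would match carbamoylmethyl remains open.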